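A few compounds are considered here, and "the series" means these few. Any claim that something is new, unique, unknown or untested is made for them only; others in the source may bear on it.

Measured compounds:
compound 1 `COc1ccc(C2N=C(SCc3ccccc3Cl)NC(C)=C2C(=O)Nc2ccc(F)cc2)cc1OC` — 6.2%
compound 2 `CC1=C(C(=O)Nc2ccc(F)cc2)C(c2ccc([N+](=O)[O-])cc2)N=C(SCc2ccccc2)N1` — 7.2%

In a functional assay on the whole organism (artery, strain albino) with Rattus norvegicus as the target, with a stated time of 30 min, at a dose of 10 mg/kg by the oral route (a higher number here means more inhibition at the dose given (going by the name of the read-out), a lower number less inhibition), compound 2 gives 7.2%. In this assay compound 1 gives 6.2%. The two numbers lie within the scatter of each other, so compound 2 does not stand apart from compound 1 on what has been measured; both are low readings of inhibition at the single dose.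

Compound 3 `CC1=C(C(=O)Nc2ccc(F)cc2)C(c2ccc([N+](=O)[O-])cc2)N=C(SCc2ccccc2Cl)N1` is the next compound, not yet measured in this assay. It differs from compound 2 by chloro in place of hydrogen on an aromatic carbon. Among the compounds with values here, no measured pair shows this difference on its own, so the size of the step can only be expected, not read off. Both measured compounds give small readings, and nothing in the numbers points to a change beyond the scatter. The step of a number 0.2 percentage points lower from compound 2 to compound 3 (within the scatter) is expected to stay within the scatter. Compound 3 is therefore estimated at 7%, with a range from 0% to 20%.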

Compound 3, a percentage reported as inhibition, in the whole organism at one dose (the size of the read-out at that dose, not a potency): 3.1%
Estimate against measurement, compound 3: 3.9 percentage points above; the measured number falls inside the stated range.
By their numbers in this assay, from the lowest: compounds 3, 1 and 2 (each within the scatter of the next).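

In this assay, the change from benzylsulfanyl to (2-chlorobenzyl)sulfanyl now has a step that can be read, a number 4.1 percentage points lower from compound 2 to compound 3 (within the scatter) and so chloro on this aromatic carbon does not set the two compounds apart. With the 2-chlorobenzyl group held in place, 4-nitrophenyl in place of 3,4-dimethoxyphenyl on a saturated ring carbon can also be read, as a number 3.1 percentage points lower from compound 1 to compound 3 (within the scatter) and this change does not separate the two compounds either. Nothing measured on these compounds offers an explanation of either reading.

Going by these compounds, whether a methoxy group, an amine or a carboxylic acid on the same aromatic carbon would give a reading beyond the scatter remains open. So does whether chloro would make any more difference with other groups on the saturated ring carbon.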